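Adding anilino to compound 3

The source may report more compounds than this note shows. Statements on the series, on what has been measured and on what is new or still open speak of the compounds shown alone.

In a functional assay on KG-1 cells (Homo sapiens) for inhibition, read by MTT assay, with a stated time of 48 h (on this read-out higher numbers stand for weaker inhibition and lower numbers for stronger inhibition), compound 3 `O=C(CCCCCCNC(=O)Cn1cnc2c(Nc3ccccc3)ncnc21)NO` gives > 50000 nM. That value is a limit of the assay and not a number.

Compound 4 `O=C(CCCCCCNC(=O)Cn1cnc2c(Nc3ccccc3)nc(Nc3ccccc3)nc21)NO` differs from compound 3 by anilino in place of hydrogen on an aromatic carbon, between two ring nitrogen atoms. Compound 1 `O=C(CCCCNC(=O)Cn1cnc2c(Nc3ccccc3)nc(Nc3ccccc3)nc21)NO` and compound 2 `O=C(CCCCCNC(=O)Cn1cnc2c(Nc3ccccc3)nc(Nc3ccccc3)nc21)NO` both carry the anilino group at that place. In this assay compound 1 gives 34700 nM. Compound 2 gives 3800 nM.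

Among the measured compounds shown here, no measured step isolates the anilino group. For the measured compounds named here, the only measured step, a 9.1-fold lower number from compound 1 to compound 2 (0.96 log units; beyond the scatter), is a change on the chain, so it bears on compound 4 only indirectly. It shows that chain changes in compounds with this group can move the value beyond the scatter.

Resting on compound 2 at 3800 nM, a large move to a lower number is expected in this assay, and the estimated step is an at least 27-fold lower number from compound 3 to compound 4 (1.44 log units; beyond the scatter). Compound 4 is estimated at 1800 nM, with an expected range of 500 nM to 7000 nM.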

Compound 4, half-maximal inhibitory concentration: 2880 nM
Estimate against measurement, compound 4: 1.6-fold (0.20 log units) below; the range from low to high includes it.
By their numbers in this assay, from the lowest: compounds 4 and 2 (each within the scatter of the next); then compound 1. At a limit, above all of these: compound 3.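

In this assay, anilino in place of hydrogen on an aromatic carbon, between two ring nitrogen atoms, now has a step of its own: an at least 17-fold lower number from compound 3 to compound 4 (1.23 log units; beyond the scatter). Compound 3 stands at a limit of the assay and not a number, so this step is a bound only: the limit of > 50000 nM in this assay, at which 1 of the 4 values shown sits.

On the chain, the values give a 12-fold lower number from compound 1 to compound 4 (1.08 log units; beyond the scatter), but only a 1.3-fold lower number from compound 2 to compound 4 (0.12 log units; within the scatter), so the chain change that moved the value earlier has no readable effect at this last step.

As far as these compounds go, whether an amine in place of anilino at this carbon would give a step of similar size stays open. From the compounds shown here alone, what a longer chain, or a carboxylic acid in place of hydroxycarbamoyl, would give also remains open.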